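The compounds below may be only part of what the source reports. "The series", "measured", "known", "first", "only" and "open" are said of these compounds alone.

Measured in a functional assay on SiHa cells (Homo sapiens) for inhibition, read by sulforhodamine B assay; on this read-out lower numbers stand for stronger inhibition of growth and higher numbers for weaker inhibition of growth:
- compound 1 `COc1ccc(-c2ccc(-c3ccc(-c4nc5cc(C)ccc5[nH]4)cc3)cc2)cc1OC`: 3510 nM
- compound 2 `COc1cc(-c2ccc(-c3ccc(-c4nc5cc(C)ccc5[nH]4)cc3)cc2)cc(OC)c1OC`: 170 nM
- compound 3 `FC(F)(F)c1ccc(-c2ccc(-c3ccc(-c4nc5ccccc5[nH]4)cc3)cc2)cc1`: 100000 nM

Of these three, compound 2 has the lowest number and so shows the strongest inhibition of growth. Compound 1 and compound 3 both lie above it, beyond the scatter.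

The compound still to be measured, compound 4 `COc1cc(-c2ccc(-c3ccc(-c4nc5ccccc5[nH]4)cc3)cc2)cc(OC)c1OC`, differs from compound 2 in one place: hydrogen in place of methyl on an aromatic carbon, which turns 5-methyl-1H-benzimidazol-2-yl to 1H-benzimidazol-2-yl (hydrogen in place of methyl on an aromatic carbon).

Among the measured compounds shown here, only one measured step isolates a single change, and it is a large one: a 21-fold lower number from compound 1 to compound 2 (1.31 log units; beyond the scatter). That step adds a methoxy elsewhere in the structure, so it says nothing direct about losing a methyl. Compound 3 carries the same 1H-benzimidazol-2-yl as compound 4 and has a much higher number, but it also differs from compound 4 elsewhere, so its value cannot be pinned on the missing methyl.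

With no direct evidence, no step beyond the scatter is expected in this assay, although the uncertainty is wide. The expected change is a 1.3-fold higher number from compound 2 to compound 4 (0.11 log units; within the scatter). The estimated value for compound 4 is 220 nM, with an expected range from 60 nM to 900 nM.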

Compound 4, concentration for 50% growth inhibition: 4980 nM
Compound 4: middle estimate off by 23-fold (1.35 log units), on the low side, outside the stated range (above it).
By their numbers in this assay, from the lowest: compound 2; then compounds 1 and 4 (each within the scatter of the next); then compound 3.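

In this assay, taking the methyl off the 5-methyl-1H-benzimidazol-2-yl group is far from a neutral edit: there is a 29-fold higher number from compound 2 to compound 4 (1.47 log units; beyond the scatter), a large step beyond the scatter. Among the compounds shown here, until now, the only single-change step concerned a methoxy elsewhere in the structure, whereas this one shows that a single carbon on an aromatic carbon of the fused two-ring system can by itself decide much of the growth inhibition seen with compound 2. Nothing available explains why this one carbon matters so much, so the result records the size of the effect and not its cause.

The compounds shown leave open whether methyl is special at this position, or whether an ethyl, a chlorine or a methoxy group on the same carbon would do as well or better. As far as these compounds go, it also remains open whether the methyl counts for as much in other parts of the series, since compound 1 has no partner here that differs from it only by this hydrogen.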